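Exchanging the chain-end group of compound 1

The source may hold more compounds than are shown below. What is called first, only, known or untested is meant among the compounds shown, and "the series" means these compounds.

Compound 1 `CC/N=C(/NC#N)NCCCCn1nc(-c2ccccc2)ccc1=O` is the parent of this small set. In a functional assay on the whole organism (stomach) with Rattus norvegicus as the target (a lower number here means that less compound is needed, a higher number that more compound is needed for the effect), compound 1 gives 92 mg/kg, the lowest of the two numbers reported; compound 3 `CC/N=C(/NC#N)NCCCCn1nc(-c2ccccc2)cc(C)c1=O`, with methyl in place of hydrogen on an aromatic carbon, gives 100 mg/kg, and the step of a 1.1-fold higher number from compound 1 to compound 3 (0.04 log units; within the scatter). Compound 2 `CC/N=C(/NC#N)NCCCCn1nc(-c2ccccc2)c(C)cc1=O`, the other methyl variant, reaches only a limit of this assay, > 100 mg/kg. Compound 4 `C/N=C(\S)NCCCCn1nc(-c2ccccc2)ccc1=O` changes a different part: a group of 4 heavy atoms (2 carbon, 1 nitrogen, 1 sulfur; no ring) in place of a group of 7 heavy atoms (4 carbon, 3 nitrogen; no ring), on an amine nitrogen. Neither measured step touches this amine nitrogen, and both stay within the scatter, so they give no direction for the new group. Compound 4 is therefore expected to sit near its parent, with a 1.0-fold lower number from compound 1 to compound 4 (0.01 log units; within the scatter) and an estimated 90 mg/kg, ranging from 30 mg/kg to 270 mg/kg.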

Compound 4, dose for half-maximal effect: 28.9 mg/kg
Compound 4: middle estimate off by 3.1-fold (0.49 log units), on the high side, and the stated range ends above it.
By their numbers in this assay, from the lowest: compound 4; then compounds 1 and 3 (each within the scatter of the next).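

Among the compounds shown here, exchanging the chain-end group on the amine nitrogen gives a 3.2-fold lower number from compound 1 to compound 4 (0.50 log units; beyond the scatter) in this assay, the first step here to clear the scatter. The methyl step from compound 1 to compound 3 stayed within the scatter, so this amine nitrogen is the first place shown where a change clearly moves the number. Nothing shown explains why this exchange lowers the number. The whole group changes at once, so the part played by sulfur cannot be separated from the rest. Going by these compounds, whether an oxygen in place of that sulfur, an amine or a carboxylic acid would do the same remains open.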